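A few compounds are considered here, and "the series" means these few. Any claim that something is new, unique, unknown or untested is made for them only; others in the source may bear on it.

Working notes on the series in a functional assay on MCF7 cells (Homo sapiens) for antiproliferative activity, read by MTT assay, with a stated time of 72 h; a lower number here means a stronger inhibitor, a higher number a weaker inhibitor. Compound 1 `CN(C)CCn1cccc1/C=N/NC(=O)Nc1ccc(Oc2ccnc3[nH]ccc23)c(F)c1` carries the entry "not determined" (no result reported), so it adds no number. Compound 2 `CCN(CC)CCCn1cccc1/C=N/NC(=O)Nc1ccc(Oc2ccnc3[nH]ccc23)c(F)c1` gives 3390 nM, and compound 3 `O=C(N/N=C/c1cccn1CCCN1CCCCC1)Nc1ccc(Oc2ccnc3[nH]ccc23)c(F)c1` gives 4840 nM. Among the compounds with values here, these are the only two numbers so far and they lie within the scatter of each other, so compound 3 stands level with compound 2.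

The next change leads to compound 4 `CN1CCN(CCCn2cccc2/C=N/NC(=O)Nc2ccc(Oc3ccnc4[nH]ccc34)c(F)c2)CC1`: 4-methylpiperazin-1-yl in place of piperidin-1-yl on a saturated chain carbon, three bonds along the chain from an aromatic nitrogen. Cut one bond further out, 3-(piperidin-1-yl)propyl becomes 3-(4-methylpiperazin-1-yl)propyl.

Within the data shown here, one measured step bears on this change: a 1.4-fold higher number from compound 2 to compound 3 (0.15 log units; within the scatter). It replaces diethylamino with piperidin-1-yl at the same place on the chain and stays within the scatter. Among the measured compounds shown here, that single step is thin evidence, and no measured compound carries 4-methylpiperazin-1-yl. In this assay no step beyond the scatter is therefore expected, and neither direction is favoured. The estimated step is a 1.1-fold lower number from compound 3 to compound 4 (0.03 log units; within the scatter). For compound 4 the expected value is 4500 nM, with an estimated range of 1800 nM to 11000 nM.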

Compound 4, half-maximal inhibitory concentration: 3740 nM
Compound 4: middle estimate off by 1.2-fold (0.08 log units), on the high side, within the range that was stated.
By their numbers in this assay, from the lowest: compounds 2, 4 and 3 (each within the scatter of the next).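

In this assay the exchange of piperidin-1-yl for 4-methylpiperazin-1-yl on a saturated chain carbon, three bonds along the chain from an aromatic nitrogen, gives a 1.3-fold lower number from compound 3 to compound 4 (0.11 log units; within the scatter) and stays level, and the exchange of diethylamino for the same group gives a 1.1-fold higher number from compound 2 to compound 4 (0.04 log units; within the scatter) and also stays level. The position now holds an open-chain amine and two different six-membered non-aromatic rings, one with 1 hetero atom and one with 2, and compounds 2, 3 and 4 cannot be told apart in this read-out; the earlier pair alone offered one step and no ring with a second nitrogen. Nothing measured on these compounds accounts for this flat result, so no reason for it can be offered.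

Going by these compounds, it remains open whether a morpholin-4-yl group, a carboxylic acid or a neutral hydroxyl in place of the amine at the end of the propyl chain would give a step beyond the scatter. The effect of a shorter or longer chain also stays unresolved, since compound 1, with its 2-(dimethylamino)ethyl chain, has no number to compare.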